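The source may hold more compounds than are shown below. What is called first, only, known or untested is meant among the compounds shown, and "the series" means these compounds.

Within the data shown here, in a functional assay on A549 cells (Homo sapiens) for cytotoxicity, read by MTT assay, with a stated time of 48 h (on this read-out higher numbers stand for weaker inhibition and lower numbers for stronger inhibition), compound 1 `COc1c(OCCCCN2CCNCC2)cc(O)c2c(=O)cc(-c3ccccc3)oc12` gives 1740 nM, the only actual number available in this small set. Compound 2 `CN1CCN(CCCOc2c(O)cc(O)c3c(=O)cc(-c4ccccc4)oc23)CC1` is recorded only as a limit, > 100000 nM. Among the measured compounds shown here, no measured step connects any two compounds, so nothing shows directly how a single change moves the read-out.

Compound 3 `COc1c(OCCCCN2CCCCC2)cc(O)c2c(=O)cc(-c3ccccc3)oc12` keeps the shared core and the chain of compound 1 and changes only the terminal ring: piperidin-1-yl in place of piperazin-1-yl on a saturated chain carbon, four bonds along the chain from an oxygen on an aromatic ring. This places piperidin-1-yl in place of piperazin-1-yl on a saturated chain carbon, four bonds along the chain from an oxygen on an aromatic ring. The expectation therefore starts from compound 1 at 1740 nM, and no shift beyond the usual scatter is anticipated in this assay. The expected result is a 1.1-fold higher number from compound 1 to compound 3 (0.06 log units; within the scatter), with no firm direction. Compound 3 is estimated at 2000 nM, with an expected range of 700 nM to 6500 nM.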

Compound 3, half-maximal inhibitory concentration: 1150 nM
Estimate against measurement, compound 3: 1.7-fold (0.24 log units) above; the range from low to high includes it.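

In this assay, among these compounds, the first readable step at this place is a 1.5-fold lower number from compound 1 to compound 3 (0.18 log units; within the scatter): with piperidin-1-yl in place of piperazin-1-yl on a saturated chain carbon, four bonds along the chain from an oxygen on an aromatic ring, the two values lie within the scatter of each other. The terminal ring can therefore give up the hydrogen-bond donor of piperazin-1-yl here without a step beyond the scatter, which compound 1 alone could not show. Nothing given here bears on why the two values stay together. From the compounds shown here alone, it remains open whether a terminal group of another kind, such as morpholin-4-yl or an open-chain dimethylamino group, would also stay within the scatter of compound 1. Also open, going by these compounds, is how a longer chain carrying piperidin-1-yl would read in this assay.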